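Compound 4: swapping an aryl amide for pentyl

A few compounds are considered here, and "the series" means these few. Any claim that something is new, unique, unknown or untested is made for them only; others in the source may bear on it.

compound 1 `COc1ccccc1NC(=O)COc1cc(C)nc2ccc(C(F)(F)F)cc12`: > 128000 nM (a limit)
compound 2 `COc1ccc2nc(C)cc(OCC(=O)Nc3ccc(Br)cc3)c2c1`: > 125000 nM (a limit)
compound 3 `COc1ccc2nc(C)cc(OCC(=O)Nc3ccc(-c4ccccc4)cc3)c2c1`: > 126000 nM (a limit)
compound 4 `CCCCCNC(=O)COc1cc(C)nc2ccc(OC)cc12`: not yet measured

In an ADME assay on HepG2 cells (Homo sapiens) for cytotoxicity, read by trypan blue exclusion, with a stated time of 48 h, in the presence of a further agent that is not named here (on this read-out lower numbers stand for higher toxicity in this test and higher numbers for lower toxicity in this test), compound 2 gives > 125000 nM, which is a limit and not a number. The entries for compound 1 and compound 3 are limits too, so this small set holds no exact value.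

The next change leads to compound 4, with pentyl in place of 4-bromophenyl on an amide-type nitrogen. Among the measured compounds shown here, only one measured step is available, a step that the two limits leave unreadable from compound 2 to compound 3. It puts phenyl in place of bromo on an aromatic carbon, not on the amide-type nitrogen, and it offers no size to carry over. Compound 2, at > 125000 nM, therefore gives a starting limit rather than a firm baseline.

In this assay, no step beyond the usual scatter is expected, and no direction can be predicted, so the estimated change is a step that the limit leaves unreadable from compound 2 to compound 4. For compound 4, the estimated value is 150000 nM, with an expected range of 60000 nM to 200000 nM.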

Compound 4, half-maximal cytotoxic concentration: > 158000 nM
Compound 4: no number, only a limit (the forecaster's own chance of this, stated with the estimate: 80%); middle value at least 1.0-fold (0.02 log units) away from the limit.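

Compound 2 and compound 4 both carry limits rather than exact numbers, so the step from 4-bromophenyl to pentyl on the amide-type nitrogen cannot be read. The compounds shown leave open at what concentration, if any, each one becomes toxic to these cells.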